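The compounds below may be only part of what the source reports. "The series", "measured", "known", "first", "only" and "open" are said of these compounds alone.

Measured compounds:
compound 1 `CC[C@H]1OC(=O)[C@H](C)[C@@H](O[C@H]2C[C@@](C)(OC)[C@@H](O)[C@H](C)O2)[C@H](C)[C@@H](O[C@@H]2O[C@H](C)C[C@H](N(C)C)[C@H]2O)[C@](C)(O)C[C@@H](C)CN(CCCNC(=O)c2c(C)nn(C)c2Cl)[C@H](C)[C@@H](O)[C@]1(C)O` — 2.2
compound 2 `CCCCCCCC(=O)NCCCO[C@H]1[C@H](C)O[C@@H](O[C@H]2[C@H](C)[C@@H](O[C@@H]3O[C@H](C)C[C@H](N(C)C)[C@H]3O)[C@](C)(OC)C[C@@H](C)C(=O)[C@H](C)[C@@H](O)[C@](C)(O)[C@@H](CC)OC(=O)[C@@H]2C)C[C@@]1(C)OC` — 6.02

In a physicochemical assay for lipophilicity, read by HPLC, measured as chromatographic lipophilicity, at pH 7.4 (a lower number here means a more polar compound, a higher number a more lipophilic compound), compound 1 gives the lower of the two numbers; compound 2 sits higher, beyond the scatter. Among the compounds with values here, no step between them is counted, as they differ in more than one place. Compound 3 `CCCCC(=O)NCCCN1C[C@H](C)C[C@@](C)(O)[C@H](O[C@@H]2O[C@H](C)C[C@H](N(C)C)[C@H]2O)[C@@H](C)[C@H](O[C@H]2C[C@@](C)(OC)[C@@H](O)[C@H](C)O2)[C@@H](C)C(=O)O[C@H](CC)[C@@](C)(O)[C@H](O)[C@H]1C` is not yet measured. It differs from compound 1 in one place: butyl in place of 5-chloro-1,3-dimethyl-1H-pyrazol-4-yl on a carbonyl carbon. The step from compound 1 to compound 3 in this assay is expected to be small and upward, close to the scatter, estimated as a number 0.30 log units higher from compound 1 to compound 3 (within the scatter). Compound 3 is therefore expected to give about 2.5, within 1.9 to 3.1.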

Compound 3, distribution coefficient: 2.72
Beside the measured number, compound 3's estimate is 0.22 log units below it; measured number inside the range.
By their numbers in this assay, from the lowest: compound 1; then compound 3; then compound 2.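

In this assay, within the data shown here, the change of 5-chloro-1,3-dimethyl-1H-pyrazol-4-yl to butyl on a carbonyl carbon gives the first step that can be read at one place, a number 0.52 log units higher from compound 1 to compound 3 (beyond the scatter), a modest step beyond the scatter. Among these compounds, at this position, then, a five-membered aromatic ring of 8 heavy atoms gives way to an open chain of 4 heavy atoms with only this rise in the number. No measurement shown here accounts for the rise. From the compounds shown here alone, whether it follows the loss of the ring or the chain itself stays open; a phenyl or cyclohexyl group on the same carbonyl carbon would separate the two.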